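Cyclopropyl to carbamoylphenyl on a fused pyridone core

The source may report more compounds than this note shows. Statements on the series, on what has been measured and on what is new or still open speak of the compounds shown alone.

Compound 1 `C[C@H](Nc1ccnc(N)n1)c1cc2ccc(F)cn2c(=O)c1-c1ccccc1`: "not determined" (no result reported)
Compound 2 `C[C@H](Nc1nc(N)nc(N)c1C#N)c1c(-c2ccccc2)c(=O)n2cc(F)ccc2c1C1CC1`: 91%

Among the measured compounds shown here, compound 2 stands alone with a number in an ADME assay on microsomes from liver (Homo sapiens), read by LC-MS, using NADPH, with a stated time of 30 min, tested at 1 uM (a higher number here means that more of the compound is left, a lower number that less of the compound is left), where it gives 91%; compound 1 has no result there, so no comparison between measured compounds is possible. Compound 3 `C[C@H](Nc1nc(N)nc(N)c1C#N)c1c(-c2ccccc2)c(=O)n2cc(F)ccc2c1-c1ccc(C(N)=O)cc1` differs from compound 2 in one place: 4-carbamoylphenyl in place of cyclopropyl on an aromatic carbon. For the measured compounds named here, with no measured step to rest on, the expected change from compound 2 to compound 3 in this assay is a number 11 percentage points lower from compound 2 to compound 3 (beyond the scatter), a modest move downward that could also fall within the scatter. Compound 3 is therefore expected to give 80%, with a range from 55% to 97%.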

Compound 3, percent of the compound remaining: 105%
Estimate against measurement, compound 3: 25 percentage points below; measured number above the stated range.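

The position on the aromatic carbon that carries cyclopropyl in compound 2 also takes 4-carbamoylphenyl, a group of more heavy atoms with an aromatic ring and an amide. In this assay, among the compounds shown here, this change gives a number 14 percentage points higher from compound 2 to compound 3 (beyond the scatter) and so brings no loss of remaining compound. Nothing shown accounts for the rise.

As far as these compounds go, whether the amide or the phenyl ring carries this result stays open. So does the outcome with plain phenyl, a 4-carboxyphenyl group or a simple amine at this carbon.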